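The source may hold more compounds than are shown below. What is called first, only, known or untested is meant among the compounds shown, and "the series" means these compounds.

Three compounds share one core. Compound 1 `COc1cc(-c2cc(C(=O)/C=C/c3ccccc3)nc3cc(-c4ccccc4)nn23)cc(OC)c1OC` carries a (2-phenylethenyl)carbonyl group, and in an ADME assay on HEK293 cells (Homo sapiens) for antiproliferative activity, read by MTT assay, with a stated time of 24 h (a lower number here means a stronger inhibitor, a higher number a weaker inhibitor), compound 1 gives 44800 nM. Compound 2 `COc1cc(-c2cc(/C=C/C(=O)c3ccccc3)nc3cc(-c4ccccc4)nn23)cc(OC)c1OC` carries 2-benzoylethenyl instead. In this assay compound 2 reaches only a limit of the assay, >= 100000 nM, not a number. The step of an at least 2.2-fold higher number from compound 1 to compound 2 (0.34 log units; beyond the scatter) is thus only a floor, because of the limit of >= 100000 nM in this assay, at which 1 of the 3 values shown sits. Compound 3 `COc1ccc(-c2cc(/C=C/C(=O)c3ccccc3)nc3cc(-c4ccccc4)nn23)cc1OC` lacks one methoxy, and in this assay compound 3 gives 51200 nM. The step of an at least 1.9-fold lower number from compound 2 to compound 3 (0.29 log units; that floor lies within the scatter) has a floor that sits within the scatter. Compound 4 `COc1cc(-c2cc(/C=C/C(=O)c3ccc(Cl)cc3)nc3cc(-c4ccccc4)nn23)cc(OC)c1OC` differs from compound 2 by chloro in place of hydrogen on an aromatic carbon. Among the compounds with values here, no measured step concerns a chloro group, so no direction follows from them. Compound 4 is therefore expected at 100000 nM, with a range from 40000 nM to 250000 nM. That estimated step, a number no higher from compound 2 to compound 4 (the limit leaves the size open), stays within the scatter.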

Compound 4, half-maximal inhibitory concentration: >= 100000 nM
Compound 4 ended at the assay's limit; the forecaster's own chance of this, stated with the estimate: 60%; the middle value sits exactly at the limit.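

Moving from the (2-phenylethenyl)carbonyl group to 2-((4-chlorophenyl)carbonyl)ethenyl in this assay gives an at least 2.2-fold higher number from compound 1 to compound 4 (0.34 log units; beyond the scatter), so the chloro-bearing group, like 2-benzoylethenyl, sits on the weaker side of compound 1. Compound 2 and compound 4 each carry a limit of the assay rather than a number, and because of this the step between them cannot be read, so any effect of chloro stays hidden: the limit of >= 100000 nM in this assay, at which 2 of the 4 values shown sit.

Still open, on these data alone, is whether any group at this place on the phenyl ring, such as an amine or a carboxylic acid, would give a readable number.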